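Thioester series: chloro to trifluoromethyl on the aryl ring

This account rests on a few compounds, and the source may have more. Where it says the series, first, only, none or still open, it means among the compounds named here.

Measured so far in a physicochemical assay for pharmacokinetics, at pH 8; on this read-out higher numbers stand for a longer-lived compound and lower numbers for a shorter-lived compound:
compound 1 `O=C(Sc1cccnc1C(=O)O)c1cccc(Cl)c1` gives 14.8 h;
compound 2 `O=C(Sc1cccnc1C(=O)O)c1ccc(Cl)cc1` gives 26.6 h;
compound 3 `O=C(Sc1cccnc1C(=O)O)c1cccc(C(F)(F)F)c1` gives 10 h.

Compound 1 and compound 2 share the same atoms joined differently; the difference between the two cores is not broken down here. From compound 1 to compound 3 the change is trifluoromethyl in place of chloro on an aromatic carbon, and in this assay it made a 1.5-fold lower number from compound 1 to compound 3 (0.17 log units; within the scatter). The unmeasured compound 4 `O=C(Sc1cccnc1C(=O)O)c1ccc(C(F)(F)F)cc1` arises from compound 2 by trifluoromethyl in place of chloro on an aromatic carbon. This is the same kind of change as before, but the place differs: meta to a large group in compound 3, para to a large group in compound 4.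

For the measured compounds named here, the step from compound 2 to compound 4 is expected to be about a 1.5-fold lower number from compound 2 to compound 4 (0.17 log units; within the scatter) in this assay, resting on the single measured step of a 1.5-fold lower number from compound 1 to compound 3 (0.17 log units; within the scatter). Compound 4 is therefore estimated at 18 h, with a likely range of 10 h to 32 h.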

Compound 4, half-life: 10.1 h
Compound 4: the middle estimate sits 1.8-fold (0.25 log units) above what was measured, and the stated range covers the measured number.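

In this assay, trifluoromethyl in place of chloro gives a 2.6-fold lower number from compound 2 to compound 4 (0.42 log units; beyond the scatter) and, on the core of compound 1, gives a 1.5-fold lower number from compound 1 to compound 3 (0.17 log units; within the scatter) for the same kind of change. The step on the core of compound 2 lies beyond the scatter and the step on the core of compound 1 lies within it, so these two pairs do not establish one size for the change that can be carried from core to core. Nothing at hand bears on what lies behind this result.

The compounds shown hold only chloro and trifluoromethyl on the aryl ring. From the compounds shown here alone, how a nitrile or a methoxy group on the same aromatic carbon would read on either core remains open.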